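The compounds below may be only part of what the source reports. "The series", "measured", "known", "first", "only" and "open" are said of these compounds alone.

Going by the values given here, compound 2 `O=C(CSc1snnc1-c1ccc(Br)cc1Br)Nc1ccc(Cl)cc1` was tested in an ADME assay on MT4 cells (Homo sapiens) for cytotoxicity, read by MTT assay, with a stated time of 5 days (a lower number here means that less compound is tolerated, a higher number that more compound is tolerated), where compound 2 gives 23300 nM, the only number among the values shown. Its companion compound 1 `O=C(CSc1snnc1-c1ccc(Br)cc1Br)Nc1ccccc1[N+](=O)[O-]` differs only on the amide-type nitrogen, carrying a 2-nitrophenyl where compound 2 carries a 4-chlorophenyl. In this assay compound 1 returns only a limit, > 235000 nM, and not a number. Among the compounds with values here, the one measured step, an at least 10-fold lower number from compound 1 to compound 2 (1.00 log units; beyond the scatter), rests on the limit of > 235000 nM in this assay, at which 1 of the 2 values shown sits, and is therefore known only as a floor on its size.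

Compound 3 `O=C(CSc1snnc1-c1ccc(Br)cc1Br)Nc1ccccc1Br` is the next step: 2-bromophenyl in place of 4-chlorophenyl on an amide-type nitrogen. The measured step bears on this change only partly, since it exchanges both the halogen for a nitro group and the position of the substituent, whereas here one halophenyl replaces another. What is measured suggests that a change at the amide-type nitrogen can move this assay by at least a modest amount, so compound 3 is expected to sit near compound 2 or somewhat above it, with the step of a 1.9-fold higher number from compound 2 to compound 3 (0.29 log units; within the scatter) estimated as small. The estimate for compound 3 is 45000 nM, in a range from 15000 nM to 235000 nM.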

Compound 3, half-maximal cytotoxic concentration: > 221000 nM
Compound 3: no number, only a limit; the forecaster's own chance of this, stated with the estimate: 30%; middle value at least 4.9-fold (0.69 log units) away from the limit.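

In this assay, 2-bromophenyl in place of 4-chlorophenyl on the amide-type nitrogen gives an at least 9.4-fold higher number from compound 2 to compound 3 (0.97 log units; beyond the scatter), so exchanging one halophenyl for another at this nitrogen is enough to produce a step beyond the scatter, which the earlier exchange of 4-chlorophenyl for 2-nitrophenyl could not show. Among the three compounds, the two carrying a 2-substituted phenyl, compound 1 and compound 3, return only limits, and compound 2, with its 4-chlorophenyl, is the only one with a number. Compound 3 gives a limit and not a number, so the new step is known only as a floor on its size: the limit of > 221000 nM in this assay, at which 1 of the 3 values shown sits.

As far as these compounds go, the step from compound 1 to compound 3 cannot be read, so how bromo and nitro on that aromatic carbon compare in this assay stays open. From the compounds shown here alone, compound 2 and compound 3 differ in both the halogen and its place on the ring, so the shift cannot be assigned to either; a 2-chlorophenyl or a 4-bromophenyl would separate the two, and how a phenyl bearing an amine or a carboxylic acid would behave also remains open.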